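This account rests on a few compounds, and the source may have more. Where it says the series, first, only, none or still open, it means among the compounds named here.

Measured so far in a functional assay on NALM-6 cells (Homo sapiens) for cytotoxicity, with a stated time of 72 h; on this read-out lower numbers stand for an effect already at smaller amounts and higher numbers for an effect only at larger amounts of compound:
compound 1 `C=C[C@@](C)(/C=C/c1ccc(OCc2ccccc2)cc1)CCC=C(C)C` — > 43400 nM, a limit of the assay, not a number.
compound 2 `COc1ccc(/C=C/[C@@](C)(/C=C/c2ccc(O)c(C=O)c2)CCC=C(C)C)cc1` — > 43400 nM, likewise a limit.
compound 3 `CCOc1ccc(/C=C/[C@@](C)(/C=C/c2ccc(O)cc2)CCC=C(C)C)cc1` — > 43400 nM, likewise a limit.

Compound 1 therefore stands where every measured compound of the series stands: at the limit of > 43400 nM in this assay, at which 3 of the 3 values shown sit, with no numerical value of its own. Compound 4 `C=C[C@@](C)(/C=C/c1ccc(Nc2ccc(Cl)c(Cl)c2)cc1)CCC=C(C)C` differs from compound 1 by (3,4-dichlorophenyl)amino in place of benzyloxy on an aromatic carbon. Among the measured compounds shown here, no step between two measured compounds is available to gauge a change of this kind, so the size of the step rests on expectation alone. The expected step of an at least 1.4-fold lower number from compound 1 to compound 4 (0.16 log units; that floor lies within the scatter) is a modest shift toward effect at smaller amounts, possibly within the scatter, and a limit remains a likely outcome. Compound 4 is estimated at 30000 nM, in the range 8000 nM to 60000 nM.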

Compound 4, half-maximal effective concentration: > 43400 nM
Compound 4: a limit, no number; the forecaster's own chance of this, stated with the estimate: 55%; middle value at least 1.4-fold (0.16 log units) away from the limit.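

In this assay compound 1 and compound 4 each give only a limit, not a number, so the step between them cannot be read. Whether any change to the shared core yields a measurable value stays open, with every compound shown at one ceiling: the limit of > 43400 nM in this assay, at which 4 of the 4 values shown sit.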